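Replacing a fluoro-hydroxyphenyl arm with a methylsulfanylphenyl arm

The source may report more compounds than this note shows. Statements on the series, on what has been measured and on what is new or still open speak of the compounds shown alone.

Measured compounds:
Compound 1 `Cn1c(=O)c(=O)n(C2CCCC2)c2nc(N/N=C/c3ccccc3)ncc21`, in a functional assay on HCT-116 cells (Homo sapiens) for antiproliferative activity, read by MTT assay (on this read-out lower numbers stand for stronger inhibition and higher numbers for weaker inhibition), compound 1 gives > 100000 nM, which is a limit of the assay rather than a number.
Compound 2 `Cn1c(=O)c(=O)n(C2CCCC2)c2nc(N/N=C/c3ccc(O)c(F)c3)ncc21`, in this assay compound 2 gives 59300 nM.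
Compound 3 `Cn1c(=O)c(=O)n(C2CCCC2)c2nc(N/N=C/c3cc([N+](=O)[O-])ccc3Cl)ncc21`, in this assay compound 3 gives 5610 nM.

All three share one core and differ only in the aryl group on a carbon with a double bond to nitrogen. Among the two real numbers, compound 2 holds the higher one; its nearest neighbour is compound 3, with an 11-fold lower number from compound 2 to compound 3 (1.02 log units; beyond the scatter). The remaining value, that of compound 1, is a limit (the limit of > 100000 nM in this assay, at which 1 of the 3 values shown sits).

Compound 4 `CSc1ccc(/C=N/Nc2ncc3c(n2)n(C2CCCC2)c(=O)c(=O)n3C)cc1` is not yet measured. It differs from compound 2 in one place: 4-(methylsulfanyl)phenyl in place of 3-fluoro-4-hydroxyphenyl on a carbon with a double bond to nitrogen.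

For the measured compounds named here, two measured steps touch the same position. From phenyl to 3-fluoro-4-hydroxyphenyl gave an at least 1.6-fold lower number from compound 1 to compound 2 (0.22 log units; that floor lies within the scatter), and from 3-fluoro-4-hydroxyphenyl to 2-chloro-5-nitrophenyl gave an 11-fold lower number from compound 2 to compound 3 (1.02 log units; beyond the scatter). Neither step involves the 4-(methylsulfanyl)phenyl group, so no direct guide exists, and the author expects for compound 4 only a step of a 1.7-fold lower number from compound 2 to compound 4 (0.23 log units; within the scatter), close to the scatter. Compound 4 is therefore estimated at 35000 nM, between 8000 nM and 150000 nM.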

Compound 4, half-maximal inhibitory concentration: 9010 nM
Estimate against measurement, compound 4: 3.9-fold (0.59 log units) above; the measured number falls inside the stated range.
By their numbers in this assay, from the lowest: compounds 3 and 4 (each within the scatter of the next); then compound 2. At a limit, above all of these: compound 1.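

The step to 4-(methylsulfanyl)phenyl gives a 6.6-fold lower number from compound 2 to compound 4 (0.82 log units; beyond the scatter), and with a 1.6-fold higher number from compound 3 to compound 4 (0.21 log units; within the scatter) this group cannot be told apart in this assay from 2-chloro-5-nitrophenyl. Methylsulfanyl in place of hydrogen on an aromatic carbon gives an at least 11-fold lower number from compound 1 to compound 4 (1.04 log units; beyond the scatter), so a single group on the phenyl ring, with neither chloro nor nitro, is enough for a change beyond the scatter. Compound 1 stands at a limit rather than a number, so that step is only a floor: the limit of > 100000 nM in this assay, at which 1 of the 4 values shown sits.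

The compounds shown leave open whether the sulfur matters or whether a methoxy or dimethylamino group in place of methylsulfanyl would give a similar number. They also leave open which of the fluoro and hydroxy parts of 3-fluoro-4-hydroxyphenyl goes with the higher number of compound 2.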